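The compounds below may be only part of what the source reports. "The series", "measured", "known", "first", "only" and "open" are said of these compounds alone.

Measured compounds in an assay on isolated protein for inhibition of glutathione S-transferase Mu 2 (Homo sapiens), with a stated time of 10 min; on this read-out higher numbers stand for weaker inhibition and lower numbers for stronger inhibition:

compound 1 `O=C(CCC(=O)OCCCCCCSc1ccc([N+](=O)[O-])c2nonc12)Nc1ccccc1F` — compound 1 gives 350 nM
compound 2 `O=C(CCC(=O)OCCCCCCSc1ccc([N+](=O)[O-])c2nonc12)Nc1ccccc1Cl` — compound 2 gives 330 nM
compound 3 `Cc1ccccc1NC(=O)CCC(=O)OCCCCCCSc1ccc([N+](=O)[O-])c2nonc12` — compound 3 gives 440 nM

All three share one core and differ only in the group on the aromatic ring attached to the amide nitrogen. For the measured compounds named here, the steps are a 1.1-fold lower number from compound 1 to compound 2 (0.03 log units; within the scatter), a 1.3-fold higher number from compound 1 to compound 3 (0.10 log units; within the scatter) and a 1.3-fold higher number from compound 2 to compound 3 (0.12 log units; within the scatter); each lies within the scatter, so compound 3 stands within the usual spread of both compound 1 and compound 2, and no compound separates from the others in this assay.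

Compound 4 `O=C(CCC(=O)OCCCCCCSc1ccc([N+](=O)[O-])c2nonc12)Nc1ccc(F)cc1` carries the change (4-fluorophenyl in place of 2-methylphenyl on an amide-type nitrogen). Going by the values given here, no measured step covers this exact change: the three steps exchange fluoro, chloro and methyl at one place on the ring, whereas here the ring carries fluorine at a different place. What the steps do show is that swapping methyl for a halogen on this ring leaves the number within the scatter, as in a 1.3-fold higher number from compound 2 to compound 3 (0.12 log units; within the scatter) and a 1.3-fold higher number from compound 1 to compound 3 (0.10 log units; within the scatter). On that basis no step beyond the scatter is expected in this assay, in either direction, and the estimated step is a 1.2-fold lower number from compound 3 to compound 4 (0.06 log units; within the scatter).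

Compound 4 is therefore estimated at 380 nM in this assay, with a range from 190 nM to 760 nM.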

Compound 4, half-maximal inhibitory concentration: 320 nM
For compound 4 the middle estimate is 1.2-fold (0.07 log units) above the measured one; low and high end bracket the measured number.
By their numbers in this assay, from the lowest: compounds 4, 2, 1 and 3 (each within the scatter of the next).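

In this assay the ring on the amide-type nitrogen now shows a change in where its group sits, not only in which group it carries. The closest comparison is 4-fluorophenyl in place of 2-fluorophenyl, which keeps the halogen and gives a 1.1-fold lower number from compound 1 to compound 4 (0.04 log units; within the scatter), so among these compounds the place of the fluorine does not shift the number beyond the scatter. The same holds when 4-fluorophenyl replaces the other two rings, with a 1.0-fold lower number from compound 2 to compound 4 (0.01 log units; within the scatter) and a 1.4-fold lower number from compound 3 to compound 4 (0.14 log units; within the scatter), and all four compounds now sit within the scatter of their neighbours in the order of their numbers; no measurement at hand bears on why they lie so close together.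

As far as these compounds go, all four rings carry one fluoro, chloro or methyl group, so it stays open whether an amine, a carboxylic acid or a methoxy group on this ring would move the number beyond the scatter. Also open, from the compounds shown here alone, is what a longer chain in the shared core, or an amide in place of its ester, would do in this assay, and whether the flat picture at this ring would survive such a change.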